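Methyl on the Ring Nitrogen and Cell Tolerance

The source may report more compounds than this note shows. Statements on the series, on what has been measured and on what is new or still open speak of the compounds shown alone.

Compound 1, `CC(=O)Nc1ccc(-c2nc3cc(C(F)(F)F)ccc3n2C)cc1`: 15000 nM
Compound 2, `CCC(=O)Nc1ccc(-c2nc3cc(C(F)(F)F)ccc3[nH]2)cc1`: a limit of the assay, >= 100000 nM

In an ADME assay on MT4 cells (Homo sapiens) for cytotoxicity, read by MTT assay, with a stated time of 96 h (a higher number here means that more compound is tolerated, a lower number that less compound is tolerated), compound 1 gives 15000 nM. Compound 2 gives no number in this assay but only a limit, >= 100000 nM. This is the limit of >= 100000 nM in this assay, at which 1 of the 2 values shown sits. Compound 3, `CCC(=O)Nc1ccc(-c2nc3cc(C(F)(F)F)ccc3n2C)cc1`, is the next compound to be measured and differs from compound 2 in one place: methyl in place of hydrogen on an aromatic nitrogen. Among the compounds with values here, no step between two measured compounds covers this change, so its size cannot be read off directly. Compound 1 carries the same methyl on the ring nitrogen as compound 3 and returns a measured number rather than a limit, which suggests the methyl may lower the amount tolerated. Compound 3 is therefore expected at about 25000 nM, within 7000 nM to 100000 nM, an expected step of an at least 4.0-fold lower number from compound 2 to compound 3 (0.60 log units; beyond the scatter) toward less tolerated, though a limit reading remains possible.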

Compound 3, half-maximal cytotoxic concentration: 8000 nM
For compound 3 the middle estimate is 3.1-fold (0.49 log units) above the measured one; measured number inside the range.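

In this assay, methyl in place of hydrogen on an aromatic nitrogen now has a measured effect, and it is large: an at least 12-fold lower number from compound 2 to compound 3 (1.09 log units; beyond the scatter). From the compounds shown here alone, compound 2 stands only at a limit of the assay, so this step gives a minimum size and the full size stays unknown: the limit of >= 100000 nM in this assay, at which 1 of the 3 values shown sits. With the methyl already on the ring nitrogen, methyl in place of hydrogen on a saturated chain carbon bound to a carbonyl carbon gives a 1.9-fold lower number from compound 1 to compound 3 (0.27 log units; within the scatter), so compound 1 and compound 3 cannot be told apart here, and the ring nitrogen is the place where a change has shown an effect so far.

Going by these compounds, whether the ring nitrogen methyl has a step of the same size on compound 1 remains open. So does the effect of an ethyl or a longer chain on that nitrogen, or of an amine on the amide chain.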